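Adding an Amino Group to a Short-Chain Antagonist

The source may hold more compounds than are shown below. What is called first, only, known or untested is meant among the compounds shown, and "the series" means these compounds.

Of the compounds shown here, two have been measured so far. Compound 1, `COc1cc(/C=C/C(=O)NCCN2CCCCC2C)cc(OC)c1OC`, gives in an assay on C6 cells for antagonist activity at prostaglandin E2 receptor EP2 subtype (Homo sapiens), read by TR-FRET, with stated times of 10 min and 40 min, tested at 1 uM (a lower number here means a stronger inhibitor, a higher number a weaker inhibitor), only a limit, > 1000 nM, not a number. Among the compounds with values here, compound 2, `COc1cc(CCC(=O)NCCn2c(C)cc3ccccc32)cc(OC)c1OC`, gives in this assay 214 nM, the only actual number among the two results. The other result sits at the limit of > 1000 nM in this assay, at which 1 of the 2 values shown sits. Compound 3, `COc1cc(C(N)CC(=O)NCCn2c(C)cc3ccccc32)cc(OC)c1OC`, has not yet been measured. It differs from compound 2 by a single change: amino in place of hydrogen on a saturated chain carbon bound to an aromatic carbon and a saturated chain carbon. Within the data shown here, no measured pair differs in just one place, so there is no directly comparable step to lean on, and the direction of the effect cannot be read from the data. For compound 3 the step is expected to be a 1.9-fold higher number from compound 2 to compound 3 (0.27 log units; within the scatter), a modest move toward weaker inhibition that may well fall within the usual scatter. Compound 3 is therefore estimated at 400 nM, most likely between 100 nM and 2000 nM.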

Compound 3, antagonist equilibrium constant: 410 nM
Compound 3: the middle estimate sits 1.0-fold (0.01 log units) below what was measured; the measured number falls inside the stated range.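

Within the data shown here, this is the first pair that differs in one place, so the effect of the change can now be read directly. In this assay, amino in place of hydrogen on a saturated chain carbon bound to an aromatic carbon and a saturated chain carbon gives a 1.9-fold higher number from compound 2 to compound 3 (0.28 log units; within the scatter), so this carbon carries the amino group and the two compounds cannot be told apart by this measurement. Nothing shown accounts for this result.

Going by these compounds, whether a hydroxyl group or a dimethylamino group on the same carbon would also leave the number within the scatter of compound 2 stays open. A single pair also cannot show whether an amino group would behave the same way elsewhere on the chain or on a different core.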